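Swapping the Ring on the Double-bonded Nitrogen

The source may report more compounds than this note shows. Statements on the series, on what has been measured and on what is new or still open speak of the compounds shown alone.

compound 1 `CC(=O)NC[C@H]1CN(c2ccc(-c3ccc(/C=N/N4CCN(C)CC4)nc3)c(F)c2)C(=O)O1` — 79%
compound 2 `CC(=O)NC[C@H]1CN(c2ccc(-c3ccc(/C=N/N4CC[S+]([O-])CC4)c(O)c3)c(F)c2)C(=O)O1` — 88%

In an ADME assay on isolated protein for inhibition of Amine oxidase [flavin-containing] A (Homo sapiens), read by luminescence, with stated times of 15 min and 60 min, tested at 30 uM (on this read-out lower numbers stand for less inhibition and higher numbers for more inhibition at the one concentration tested (going by the name of the read-out)), compound 1 gives 79%, the smaller of the two figures, while compound 2 gives 88%, a gap that lies within the scatter of repeated measurements. Compound 3 `CC(=O)NC[C@H]1CN(c2ccc(-c3ccc(/C=N/N4CCSCC4)nc3)c(F)c2)C(=O)O1` has not been measured. It differs from compound 1 in one place: thiomorpholin-4-yl in place of 4-methylpiperazin-1-yl on a double-bonded nitrogen. Among the compounds with values here, no measured pair shows this change, so the step from compound 1 to compound 3 is expected to be a number 1 percentage points lower from compound 1 to compound 3 (within the scatter), nothing beyond the scatter. Compound 3 is therefore estimated at 78%, between 60% and 92%.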

Compound 3, a percentage reported as inhibition, at one concentration (the size of the read-out at that concentration, not a potency): 75%
The estimate for compound 3 lay 3 percentage points above the measured number; the measured number falls inside the stated range.
By their numbers in this assay, from the lowest: compounds 3, 1 and 2 (each within the scatter of the next, the first and the last beyond it).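

In this assay, within the data shown here, this pair gives the first direct reading of a change at this position, with the step of a number 4 percentage points lower from compound 1 to compound 3 (within the scatter). At this place on the core of compound 1, thiomorpholin-4-yl thus stands in for 4-methylpiperazin-1-yl without a change beyond the scatter, although the two rings differ in their atoms. Nothing measured here offers an explanation for this result. The compounds shown leave open whether morpholin-4-yl or an open-chain dimethylamino group on the same double-bonded nitrogen would also stay within the scatter.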